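A Second Fluorine on the Amide-Bound Phenyl Ring

The compounds below may be only part of what the source reports. "The series", "measured", "known", "first", "only" and "open" are said of these compounds alone.

Of the compounds shown here, three sharing one core have been tested in a functional assay on U-937 cells (Homo sapiens) for cytotoxicity, read by MTT assay, with a stated time of 24 h; on this read-out lower numbers stand for stronger inhibition and higher numbers for weaker inhibition. Compound 1 `CCCCCCCCCCn1cc(Cn2nc(N)c3c(C(F)(F)F)cc(-c4ccccc4)nc32)nn1` carries a nonyl chain on the saturated carbon bound to the aromatic nitrogen and gives 27.1 ug/mL. Compound 2 `Cc1ccc(NC(=O)Cn2cc(Cn3nc(N)c4c(C(F)(F)F)cc(-c5ccccc5)nc43)nn2)cc1` instead carries a (4-methylphenyl)carbamoyl group there and gives 65.3 ug/mL, a 2.4-fold higher number from compound 1 to compound 2 (0.38 log units; beyond the scatter). Compound 3 `Nc1nn(Cc2cn(CC(=O)Nc3cccc(F)c3)nn2)c2nc(-c3ccccc3)cc(C(F)(F)F)c12` carries a (3-fluorophenyl)carbamoyl group and gives 43.5 ug/mL; this is the second highest of the three numbers, and both the gap from compound 1 a 1.6-fold higher number from compound 1 to compound 3 (0.21 log units; within the scatter) and the gap from compound 2 a 1.5-fold lower number from compound 2 to compound 3 (0.18 log units; within the scatter) lie within the usual scatter.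

Compound 4 `Nc1nn(Cc2cn(CC(=O)Nc3c(F)cccc3F)nn2)c2nc(-c3ccccc3)cc(C(F)(F)F)c12` differs from compound 3 in one place: 2,6-difluorophenyl in place of 3-fluorophenyl on an amide-type nitrogen. Going by the values given here, the only measured step that touches the same spot is the swap of aryl groups on the amide-type nitrogen between compound 2 and compound 3, which stayed within the scatter. On that basis no step beyond the scatter is expected for compound 4, so a 1.0-fold higher number from compound 3 to compound 4 (0.01 log units; within the scatter) is the estimate, and compound 4 is expected to give about 45 ug/mL, likely between 25 ug/mL and 80 ug/mL.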

Compound 4, half-maximal inhibitory concentration: 30.6 ug/mL
Beside the measured number, compound 4's estimate is 1.5-fold (0.17 log units) above it, within the range that was stated.
By their numbers in this assay, from the lowest: compounds 1, 4, 3 and 2 (each within the scatter of the next, the first and the last beyond it).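

In this assay, going by these compounds alone, 2,6-difluorophenyl in place of 3-fluorophenyl on the amide-type nitrogen gives a 1.4-fold lower number from compound 3 to compound 4 (0.15 log units; within the scatter) and so adds no readable change, while the same group in place of 4-methylphenyl gives a 2.1-fold lower number from compound 2 to compound 4 (0.33 log units; beyond the scatter) as the first step beyond the scatter among the aryl groups at this position, though a modest one. Compared with the nonyl chain, the (2,6-difluorophenyl)carbamoyl group gives a 1.1-fold higher number from compound 1 to compound 4 (0.05 log units; within the scatter) and so cannot be told apart from it on this read-out. Nothing measured here explains these steps.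

The compounds shown leave open whether the number of fluorines or their placement matters more, which 2-fluorophenyl on the same nitrogen could help separate. They also leave open how this read-out would respond to a phenyl ring carrying an amine or a carboxylic acid, or to a chain longer than nonyl.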